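The source may hold more compounds than are shown below. What is called first, only, known or untested is meant among the compounds shown, and "the series" means these compounds.

Series notes. The three measured compounds share a thiosemicarbazide-type linkage to an amidine on a six-membered aromatic ring with one nitrogen, and differ in the saturated ring at the far end and in the substituent on the aromatic ring. Compound 1 `Cc1ccnc(/C(N)=N/NC(=S)N2CCSCC2)c1` in a functional assay on A-375 cells (Homo sapiens) for cytotoxicity, read by MTT assay, with a stated time of 72 h (on this read-out higher numbers stand for weaker inhibition and lower numbers for stronger inhibition), gives 1200 nM. Compound 2 `N/C(=N\NC(=S)N1CCOCC1)c1ccc(F)cn1` in this assay gives 1500 nM. Compound 3 `N/C(=N\NC(=S)N1CCN(c2ccccn2)CC1)c1ccc(F)cn1` in this assay gives 1400 nM; it stands second highest of the three numbers, with compound 2 nearest and compound 1 furthest, and both of those gaps lie within the scatter, so the three values read as one level.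

Compound 4 `N/C(=N\NC(=S)N1CCN(c2ccccn2)CC1)c1ccccn1` follows from compound 3 by a single change, (hydrogen in place of fluoro on an aromatic carbon). Within the data shown here, no measured pair shows this change, so nothing in the set fixes its direction. Given that compound 1, compound 2 and compound 3 all sit at one level in this assay, the step is expected to be small, a 1.3-fold higher number from compound 3 to compound 4 (0.11 log units; within the scatter), with no direction beyond the scatter. For compound 4 the expected value in this assay is 1800 nM, in a range from 800 nM to 4000 nM.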

Compound 4, half-maximal inhibitory concentration: 700 nM
The estimate for compound 4 lay 2.6-fold (0.41 log units) above the measured number, outside the stated range (below it).
By their numbers in this assay, from the lowest: compounds 4, 1, 3 and 2 (each within the scatter of the next, the first and the last beyond it).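

At the aromatic carbon two atoms from the ring nitrogen, para to a large group, the series now has its first pair differing in one place: in this assay, the change from 5-fluoropyridin-2-yl to pyridin-2-yl gives a 2.0-fold lower number from compound 3 to compound 4 (0.30 log units; within the scatter). Fluoro at this position is therefore not needed to hold the number at this level, and the single step fixes no firm direction for the change. No measured information accounts for this step.

From the compounds shown here alone, whether chloro, methoxy or an amine at the same position would give a step beyond the scatter remains open. Also open, going by these compounds, is whether hydrogen in place of fluoro gives a similar step with a different saturated ring at the far end, as in compound 2.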